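Tetramethylcyclopropyl for oxanyl on the stereodefined core

The source may report more compounds than this note shows. Statements on the series, on what has been measured and on what is new or still open speak of the compounds shown alone.

Working notes on the series. Compound 2 `Cc1cc(NC(=O)C2CCOCC2)ccc1N1CCC(N2CCCC2C)C1` carries an (oxan-4-yl)carbonyl amide; in an assay on CHO cells for displacement of a labelled ligand from histamine receptor H3 (Macaca mulatta) (a higher number here means a weaker inhibitor, a lower number a stronger inhibitor), compound 2 gives 17 nM. Compound 1 `Cc1cc(NC(=O)C2C(C)(C)C2(C)C)ccc1N1CCC(N2CCCC2C)C1` differs from it by 2,2,3,3-tetramethylcyclopropyl in place of oxan-4-yl on a carbonyl carbon and in this assay compound 1 gives 65.5 nM; the change made a 3.9-fold higher number from compound 2 to compound 1 (0.59 log units; beyond the scatter). Compound 3 `Cc1cc(N2CC[C@H](N3CCC[C@@H]3C)C2)ccc1NC(=O)C1CCOCC1` has the same atoms as compound 2 joined differently; the difference between the two cores is not broken down here. In this assay compound 3 gives 0.97 nM, the lowest number of the three measured. Compound 4 `Cc1cc(N2CC[C@H](N3CCC[C@@H]3C)C2)ccc1NC(=O)C1C(C)(C)C1(C)C` is not yet measured; it differs from compound 3 by 2,2,3,3-tetramethylcyclopropyl in place of oxan-4-yl on a carbonyl carbon, the same change as from compound 2 to compound 1, at a place described in identical words. Going by the values given here, the step from compound 3 to compound 4 is expected to be a 3.9-fold higher number from compound 3 to compound 4 (0.59 log units; beyond the scatter), resting on a 3.9-fold higher number from compound 2 to compound 1 (0.59 log units; beyond the scatter) as the only precedent. Compound 4 is therefore estimated at 3.8 nM, expected within 1.5 nM to 10 nM.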

Compound 4, inhibition constant: 0.55 nM
The estimate for compound 4 lay 6.9-fold (0.84 log units) above the measured number; measured number below the stated range.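

In this assay 2,2,3,3-tetramethylcyclopropyl in place of oxan-4-yl on a carbonyl carbon gives a 1.8-fold lower number from compound 3 to compound 4 (0.25 log units; within the scatter) and so leaves the number on the core of compound 3 within the scatter. The step seen on the core of compound 2 therefore does not carry over to the core of compound 3: the same change on two cores in this assay, a 3.9-fold higher number (0.59 log units; beyond the scatter) from compound 2 to compound 1 and a 1.8-fold lower number (0.25 log units; within the scatter) from compound 3 to compound 4, 6.8-fold (0.83 log units) apart, beyond the scatter of two such steps. This rests on a single pair on each core and shows that the size of this step depends on the core in this series, but it does not show which feature of the cores sets the two steps apart.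

Going by these compounds, whether unsubstituted cyclopropyl or piperidin-4-yl on the same carbonyl carbon would also differ between the two cores stays open. So does whether any other pair of groups behaves as this pair does.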